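Working notes: compound 4, phenethyl ether, expected agonist potency

The source may report more compounds than this note shows. Statements on the series, on what has been measured and on what is new or still open speak of the compounds shown alone.

Measured so far, all in a functional assay on HEK293 cells for agonist activity at G-protein coupled receptor 39 (Homo sapiens), read by scintillation proximity assay and inositol phosphate accumulation, with a stated time of 75 min, in the presence of a further agent that is not named here; a higher number here means that more compound is needed for the effect, a lower number that less compound is needed:
compound 1 `Cc1nn(-c2ncnc3nc[nH]c23)c2c1C(OC1CCCC1)CC(=O)N2`: 2 nM
compound 2 `CCCCCCCCOC1CC(=O)Nc2c1c(C)nn2-c1ncnc2nc[nH]c12`: 8 nM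
compound 3 `Cc1nn(-c2ncnc3nc[nH]c23)c2c1C(OC(=O)c1ccc(F)cc1)CC(=O)N2`: 4 nM

Compound 2 shows the highest of the three numbers in this assay. Its nearest neighbour is compound 3, separated by a step within the scatter; the gap to compound 1 is larger, a 4.0-fold higher number from compound 1 to compound 2 (0.60 log units; beyond the scatter), and that one lies beyond the scatter.

The next compound is compound 4 `Cc1nn(-c2ncnc3nc[nH]c23)c2c1C(OCCc1ccccc1)CC(=O)N2`. Relative to compound 2 the change is phenyl in place of hexyl on a saturated chain carbon, two bonds along the chain from an oxygen on a saturated carbon.

Going by the values given here, two measured steps bear on this. The move from the cyclopentyl ether of compound 1 to the octyl ether of compound 2 raised the number, a 4.0-fold higher number from compound 1 to compound 2 (0.60 log units; beyond the scatter), while replacing octyl with the ring-bearing (4-fluorophenyl)carbonyl group gave a 2.0-fold lower number from compound 2 to compound 3 (0.30 log units; within the scatter), within the scatter. Both show that the octyl compound 2 sits at the high end, and that groups carrying a ring return lower or equal numbers. Compound 4 keeps two chain carbons and adds a phenyl, so a step toward the values of compound 1 and compound 3 is expected, likely small and possibly within the scatter.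

For compound 4 the expected step is a 2.0-fold lower number from compound 2 to compound 4 (0.30 log units; within the scatter). The estimate for compound 4 in this assay is 4 nM, with a range from 1.5 nM to 12 nM.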

Compound 4, half-maximal effective concentration: 3 nM
Beside the measured number, compound 4's estimate is 1.3-fold (0.12 log units) above it; the range from low to high includes it.
By their numbers in this assay, from the lowest: compounds 1, 4, 3 and 2 (each within the scatter of the next, the first and the last beyond it).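

In this assay the step of a 2.7-fold lower number from compound 2 to compound 4 (0.43 log units; beyond the scatter) exchanges hexyl for phenyl, two groups with the same count of heavy atoms, so a group of equal size that carries a six-membered aromatic ring separates from the open chain beyond the scatter. The phenethyl ether also cannot be told apart from the other ring-bearing groups, with a 1.3-fold lower number from compound 3 to compound 4 (0.12 log units; within the scatter) and a 1.5-fold higher number from compound 1 to compound 4 (0.18 log units; within the scatter) both within the scatter, so a ring on the oxygen substituent reads alike whether it is a cyclopentyl, a phenethyl or a (4-fluorophenyl)carbonyl group, and compound 2 alone has no ring, although compound 3 goes against a clean split by lying within the scatter of compound 2. Nothing shown gives a reason for the difference between hexyl and phenyl at this place.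

The compounds shown leave open whether a fluorine on the phenyl of compound 4 or a phenylpropyl ether in place of the phenethyl ether would keep the number in this range. They also leave open how an amine or a carboxylic acid at the end of the chain would read in this series.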